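From 4-Chlorobenzyl to 1-Phenylethyl on a Shared Core

The source may report more compounds than this note shows. Statements on the series, on what has been measured and on what is new or still open speak of the compounds shown alone.

In a functional assay on HL-60 cells (Homo sapiens), with a stated time of 4 days (a lower number here means a stronger inhibitor, a higher number a weaker inhibitor), compound 1 (`O=C(NCc1ccccc1)c1nc[nH]c1C(=O)Nc1ccc(Cl)c(Cl)c1`) gives 7400 nM and compound 2 (`O=C(Nc1ccc(Cl)c(Cl)c1)c1nc[nH]c1C(=O)NCc1ccc(Cl)cc1`) gives 8800 nM in the same read-out, so the two values lie within the scatter of each other. Compound 3 (`C[C@H](NC(=O)c1[nH]cnc1C(=O)Nc1ccc(Cl)c(Cl)c1)c1ccccc1`) has not yet been measured. It departs from compound 2 by a single change (1-phenylethyl in place of 4-chlorobenzyl on an amide-type nitrogen), with 1-phenylethyl in place of 4-chlorobenzyl on an amide-type nitrogen, and the entering group carries one defined stereocentre. For the measured compounds named here, no measured pair covers this change. Taking compound 2 at 8800 nM as the starting point, no step beyond the scatter is expected in this assay in either direction. The estimate amounts to an expected step (a 1.1-fold lower number from compound 2 to compound 3 (0.04 log units; within the scatter)) that stays small. Compound 3 is estimated at 8000 nM (expected range 3000 nM to 20000 nM) in this measurement.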

Compound 3, half-maximal inhibitory concentration: 5900 nM
Compound 3: the middle estimate sits 1.4-fold (0.13 log units) above what was measured, within the range that was stated.
By their numbers in this assay, from the lowest: compounds 3, 1 and 2 (each within the scatter of the next).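

In this assay, the exchange of 4-chlorobenzyl for 1-phenylethyl on this amide-type nitrogen comes to a 1.5-fold lower number from compound 2 to compound 3 (0.17 log units; within the scatter). The earlier compounds shown here carried no stereocentre in this group, and compound 3 shows that a group with one defined stereocentre can stand on this nitrogen without a step beyond the scatter. No measurement here bears on why this exchange gives so small a step.

From the compounds shown here alone, what the opposite configuration at that stereocentre would give remains open. Going by these compounds, it is also open whether a longer chain such as 2-phenylethyl, or an amine or a carboxylic acid on the aromatic ring of this group, would move the number beyond the scatter.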